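An Isopropyl Step Repeated on a Second Core

This account rests on a few compounds, and the source may have more. Where it says the series, first, only, none or still open, it means among the compounds named here.

Of the compounds shown here, three have so far been tested in a functional assay on RS4-11 cells (Homo sapiens) for inhibition, read by CCK-8 assay, with a stated time of 48 h; a higher number here means a weaker inhibitor, a lower number a stronger inhibitor. Compound 1 `COc1ccc(Oc2ccccc2-c2ccsc2S(=O)(=O)NCCNC(=S)Nc2cc(C(F)(F)F)cc(C(F)(F)F)c2)cc1OC` gives 3300 nM in this assay. Compound 2 `COc1ccc(Oc2ccc(C(C)C)cc2-c2ccsc2S(=O)(=O)NCCNC(=S)Nc2cc(C(F)(F)F)cc(C(F)(F)F)c2)cc1OC` differs from it by isopropyl in place of hydrogen on an aromatic carbon, and in this assay compound 2 gives 5500 nM; the change produced a 1.7-fold higher number from compound 1 to compound 2 (0.22 log units; within the scatter). Compound 3 `O=C(NCCNS(=O)(=O)c1sccc1-c1ccccc1Oc1ccc(O)c(O)c1)Nc1cc(C(F)(F)F)cc(C(F)(F)F)c1` is built on another core; the difference between its core and that of compound 1 is not broken down here. In this assay compound 3 gives 4900 nM, and its number, together with those of compound 1 and compound 2, lies within the usual scatter, so no order among the three can be read from them.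

Compound 4 `CC(C)c1ccc(Oc2ccc(O)c(O)c2)c(-c2ccsc2S(=O)(=O)NCCNC(=O)Nc2cc(C(F)(F)F)cc(C(F)(F)F)c2)c1` has not yet been measured. It differs from compound 3 by isopropyl in place of hydrogen on an aromatic carbon. Among the measured compounds shown here, this is the same kind of change as the one made from compound 1 to compound 2, though not the same: in compound 2 the entering group sits para to a 3,4-dimethoxyphenoxy group, whereas in compound 4 it sits para to a 3,4-dihydroxyphenoxy group.

The expectation for compound 4 rests on that single earlier instance. Because a 1.7-fold higher number from compound 1 to compound 2 (0.22 log units; within the scatter) stayed within the scatter, the expected step is a 1.3-fold higher number from compound 3 to compound 4 (0.12 log units; within the scatter), again within the scatter. Compound 4 is therefore expected to give about 6500 nM in this assay, with the estimate running from 3000 nM to 14000 nM.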

Compound 4, half-maximal inhibitory concentration: 6800 nM
Beside the measured number, compound 4's estimate is 1.0-fold (0.02 log units) below it; low and high end bracket the measured number.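

In this assay, isopropyl in place of hydrogen on an aromatic carbon gave a 1.4-fold higher number from compound 3 to compound 4 (0.14 log units; within the scatter), so on this second core the change again leaves the number within the scatter. Set beside the earlier instance, the step shows no detectable difference in size, and the change carried over from one core to the other with much the same small result: the same change on two cores in this assay, a 1.7-fold higher number (0.22 log units; within the scatter) from compound 1 to compound 2 and a 1.4-fold higher number (0.14 log units; within the scatter) from compound 3 to compound 4, 1.2-fold (0.08 log units) apart, within the scatter of two such steps. Among the compounds shown here, this shows only that the step stayed small on these two cores; as neither step lies beyond the scatter, it does not show that isopropyl has any real effect on the number, nor that the same would hold on a further core.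

The compounds shown leave open whether a different group on the same aromatic carbon, such as an amine, a carboxylic acid or a longer alkyl chain, would move the number beyond the scatter. They also leave open how the 3,4-dihydroxyphenoxy group and the 3,4-dimethoxyphenoxy group would compare on an otherwise identical core, since the two cores differ in more than that one place.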